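Methyl in Place of Chloro: From Compound 3 to Compound 4

The source may report more compounds than this note shows. Statements on the series, on what has been measured and on what is new or still open speak of the compounds shown alone.

Three compounds that share one core have been examined in an assay on HEK293 cells for activation of Kir3.1/Kir3.2 (Homo sapiens), read by thallium flux; on this read-out lower numbers stand for smaller maximal responses and higher numbers for larger maximal responses. Compound 3 `Cc1cc(NC(=O)Cn2nnc(-c3ccc(Cl)c(Cl)c3)n2)n(C2CCCCC2)n1` reaches 84% in this assay, the only result given as a plain number. Compound 1 `Cc1cc(NC(=O)Cn2nnc(-c3ccccc3)n2)n(C2CC2)n1` gives > 78% in this assay, which is a limit of the read-out and not a number. Compound 2 `O=C(Cn1nnc(-c2ccccc2)n1)Nc1cc(C2(C(F)(F)F)CC2)nn1C1CCCCC1` is recorded in this assay as "not active" (no number reported), with no figure attached. Within the data shown here, the sole evidence bearing on steps is the limit of > 78% in this assay, at which 1 of the 3 values shown sits, where compound 1 sits. Among the measured compounds shown here, no step between two measured compounds can therefore be stated, and compound 3 stands as the only anchor.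

Compound 4 `Cc1cc(NC(=O)Cn2nnc(-c3ccc(Cl)c(C)c3)n2)n(C2CCCCC2)n1` has not yet been measured. It differs from compound 3 in one place: methyl in place of chloro on an aromatic carbon. Seen one bond further out, the change reads 3,4-dichlorophenyl to 4-chloro-3-methylphenyl.

For the measured compounds named here, with no comparable step in this set to lean on, the expected step of a number 6 percentage points lower from compound 3 to compound 4 (within the scatter) is small and within the usual scatter, with no clear direction. Compound 4 is estimated to reach about 78% in this assay, with a range from 55% to 95%.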

Compound 4, largest response reached (Emax), in percent of the reference or control that the assay uses: 89%
The estimate for compound 4 lay 11 percentage points below the measured number; measured number inside the range.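

Methyl in place of chloro on an aromatic carbon gives the first step that can be read in this set, in this assay: a number 5 percentage points higher from compound 3 to compound 4 (within the scatter). At this place, ortho to a chloro group and meta to a large group, a carbon-bearing methyl group can therefore stand where chlorine stood, and the maximal response of the 3,4-dichlorophenyl compound and that of the 4-chloro-3-methylphenyl compound cannot be told apart on this read-out. Nothing shown gives a cause for this step.

Among these compounds, no steps to compound 1 or compound 2 can be read, so this single step stands alone and supports no wider pattern. Open, on these data alone, is how the response behaves with a methoxy group, a nitrile or an amine at this same place on the ring.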